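A few compounds are considered here, and "the series" means these few. Any claim that something is new, unique, unknown or untested is made for them only; others in the source may bear on it.

Of the compounds shown here, two of a shared core have so far been measured in a functional assay on 786-0 cells (Homo sapiens) for inhibition, read by sulforhodamine B assay, with a stated time of 48 h, tested at 10 uM; a lower number here means less inhibition, a higher number more inhibition at the concentration tested (going by the name of the read-out). Compound 1 `O=Cc1ccc(-c2cn3ccnc3c(-c3ccc4ncn(C5CCCCC5)c4c3)n2)cc1` gives 46.7% in this assay. Among the compounds with values here, compound 2 `Fc1ccc(-c2cn3ccnc3c(-c3ccc4ncn(C5CCCCC5)c4c3)n2)cc1` gives 11.2% in this assay, which places it as the lower of the two numbers; the only measured step, a number 35.5 percentage points lower from compound 1 to compound 2 (beyond the scatter), is a fluoro in place of formyl on an aromatic carbon, and it is large.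

Compound 3 `Clc1ccc(-c2cn3ccnc3c(-c3ccc4ncn(C5CCCCC5)c4c3)n2)cc1` is the next compound, not yet measured. It differs from compound 2 by chloro in place of fluoro on an aromatic carbon, so a 4-fluorophenyl becomes a 4-chlorophenyl. Within the data shown here, no measured step compares one halogen with another; the single step from compound 1 to compound 2 swapped a formyl for a fluoro, a different kind of change, and it does not bear directly on this one. The change from compound 2 to compound 3 is therefore expected to give a step of a number 4.8 percentage points higher from compound 2 to compound 3 (within the scatter), not beyond the scatter. Compound 3 is estimated at 16%, within 0% to 36%.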

Compound 3, a percentage reported as inhibition, at one concentration (the size of the read-out at that concentration, not a potency): 12.1%
Compound 3: the middle estimate sits 3.9 percentage points above what was measured; measured number inside the range.
By their numbers in this assay, from the lowest: compounds 2 and 3 (each within the scatter of the next); then compound 1.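

In this assay, chloro in place of fluoro on this aromatic carbon gives a number 0.9 percentage points higher from compound 2 to compound 3 (within the scatter) and so the two halogens cannot be told apart at this position. Chloro in place of formyl gives a number 34.6 percentage points lower from compound 1 to compound 3 (beyond the scatter) and this large step matches the direction of the earlier change to fluoro, which sets compound 1 apart from both halogen compounds. No available evidence gives a reason for this difference.

From the compounds shown here alone, it remains open whether other groups at this position, such as a nitrile, a carboxylic acid, an amine or a methyl ester, would read like the formyl of compound 1 or like the halogens. All three compounds share the rest of the core, so they also leave open how a change elsewhere would read.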